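The source may hold more compounds than are shown below. What is called first, only, known or untested is meant among the compounds shown, and "the series" means these compounds.

Of the compounds shown here, two built on one shared core have been measured so far. In a physicochemical assay, with a stated time of 60 min, tested at 60 ug/mL (a lower number here means a weaker effect, a higher number a stronger effect of the compound at the concentration tested), compound 1 `CCOC(=O)[C@@H]1CC(=O)c2sccc2[C@H]1c1ccc(OC)cc1` gives 24.8%. Compound 2 `CCOC(=O)[C@@H]1CC(=O)c2sccc2[C@H]1c1ccc(OCC)cc1`, which carries methyl in place of hydrogen on a saturated chain carbon bound to an oxygen on an aromatic ring, gives 27% in this assay. For the measured compounds named here, the only measured step is a number 2.2 percentage points higher from compound 1 to compound 2 (within the scatter), and it does not reach beyond the scatter. Compound 1 thus stands at one end of the two numbers measured, with compound 2 lying within the scatter of it.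

Compound 3 `CCOC(=O)[C@@H]1CC(=O)c2sccc2[C@H]1c1ccc(OC)c(OC)c1` differs from compound 1 by methoxy in place of hydrogen on an aromatic carbon, the methoxy entering on an aromatic carbon of a six-membered aromatic ring of carbon only, ortho to a methoxy group. Going by the values given here, no measured step touches an aromatic carbon of that ring; the step from compound 1 to compound 2 concerns the chain on the oxygen, bears only loosely on this change, and was small. Nothing in the two numbers points to a move beyond the scatter, so the expected step of a number 2.2 percentage points higher from compound 1 to compound 3 (within the scatter) is essentially flat. Compound 3 is accordingly estimated to give 27% in this assay, within a range from 15% to 40%.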

Compound 3, a percentage reported as activity, at one concentration (the size of the read-out at that concentration, not a potency): 24.1%
Beside the measured number, compound 3's estimate is 2.9 percentage points above it; the measured number falls inside the stated range.
By their numbers in this assay, from the lowest: compounds 3, 1 and 2 (each within the scatter of the next).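

In this assay, methoxy in place of hydrogen on an aromatic carbon, ortho to a methoxy group, comes with a number 0.7 percentage points lower from compound 1 to compound 3 (within the scatter) and so gives the first reading from a carbon of that six-membered aromatic ring itself, where the earlier step concerned only the chain on the oxygen. Even with a second methoxy group on the ring, the read-out of compound 3 cannot be told apart from that of compound 1 at the concentration tested. Taken with a number 2.2 percentage points higher from compound 1 to compound 2 (within the scatter), this makes two single changes to compound 1 that both stay within the scatter, and neither compound goes against that reading. The data at hand offer no explanation for this flat result.

Going by these compounds, it remains open whether a different group on this same aromatic carbon, such as an amine, a carboxylic acid or a longer chain, would move the number beyond the scatter. Also open, on these data alone, is whether a methoxy group on another carbon of the ring, or a change to the ethyl ester on the shared core, would do so.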